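This account rests on a few compounds, and the source may have more. Where it says the series, first, only, none or still open, it means among the compounds named here.

Working notes on the series.

The shared core is seen without ring substituent in compound 2, `COc1ccc(/C(Cl)=C/C=C(\C#N)C(=O)c2c[nH]c3ccccc23)cc1`. In a functional assay for inhibition, with a stated time of 5 min, tested at 1 mM (on this read-out lower numbers stand for less inhibition and higher numbers for more inhibition at the one concentration tested (going by the name of the read-out)), compound 2 gives 61.3%. Compound 1, `COc1ccc(/C(Cl)=C/C=C(\C#N)C(=O)c2c[nH]c3ccc(Br)cc23)cc1`, carries bromo in place of hydrogen on an aromatic carbon and in this assay compound 1 gives 62.2%; the step is a number 0.9 percentage points higher from compound 2 to compound 1 (within the scatter). Compound 3, `COc1ccc(/C(Cl)=C/C=C(\C#N)C(=O)c2c[nH]c3ccccc23)cc1OC`, carries methoxy in place of hydrogen on an aromatic carbon and in this assay compound 3 gives 63.6%; the step is a number 2.3 percentage points higher from compound 2 to compound 3 (within the scatter). Among the measured compounds shown here, the three measured numbers thus sit close together, and no compound can be set apart from the others on this read-out.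

Compound 4, `COc1ccc(/C(Cl)=C/C=C(\C#N)C(=O)c2c[nH]c3ccc(Br)cc23)cc1OC`, is not yet measured in this assay. It differs from compound 3 by bromo in place of hydrogen on an aromatic carbon. For the measured compounds named here, this is the same change as the one from compound 2 to compound 1, with the place described in the same words in both cases; the two cores on which it is made differ by methoxy in place of hydrogen on an aromatic carbon. The change occurs twice among the compounds shown, once measured and once not.

The expected step is a number 0.9 percentage points higher from compound 3 to compound 4 (within the scatter), because the same change gave a number 0.9 percentage points higher from compound 2 to compound 1 (within the scatter). The expectation rests on that single measured step and on the narrow spread of the three numbers in hand, with nothing to suggest that the methoxy on the other ring alters the outcome. Compound 4 is therefore estimated at 64.5% in this assay, with a range from 54% to 74%.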

Compound 4, a percentage reported as inhibition, at one concentration (the size of the read-out at that concentration, not a potency): 80.9%
Estimate against measurement, compound 4: 16.4 percentage points below; the measured number lies above the stated range.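

In this assay the bromo change, made on the core that already carries the added methoxy, is a number 17.3 percentage points higher from compound 3 to compound 4 (beyond the scatter), and the methoxy change, made on the core that already carries bromo, is a number 18.7 percentage points higher from compound 1 to compound 4 (beyond the scatter). The bromo step therefore does not carry from one core to the other in this series: the same change on two cores in this assay, a number 0.9 percentage points higher (within the scatter) from compound 2 to compound 1 and a number 17.3 percentage points higher (beyond the scatter) from compound 3 to compound 4, 16.4 percentage points apart, beyond the scatter of two such steps. Among the compounds shown here, the methoxy step behaves alike, but this is the same four compounds read the other way and not a separate finding, and it shows only that the two changes do not add up in this one set, not why they fail to, nor whether the same would hold on any other core: the same change on two cores in this assay, a number 2.3 percentage points higher (within the scatter) from compound 2 to compound 3 and a number 18.7 percentage points higher (beyond the scatter) from compound 1 to compound 4, 16.4 percentage points apart, beyond the scatter of two such steps.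

The compounds shown hold only bromo and methoxy as these two changes, each read at a single concentration, so it stays open whether the higher number of compound 4 depends on these two groups in particular. Going by these compounds, whether fluoro in place of the bromo, or an amine or a carboxylic acid in place of the added methoxy, would give a step of the same size on these cores also stays open.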